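Fluoro in Place of Methyl: What Compound 4 Should Show

The source may report more compounds than this note shows. Statements on the series, on what has been measured and on what is new or still open speak of the compounds shown alone.

Of the compounds shown here, three built on a shared core have so far been tested in a functional assay on HBL-100 cells (Homo sapiens) for inhibition, read by sulforhodamine B assay, with a stated time of 48 h; a lower number here means a stronger inhibitor of growth, a higher number a weaker inhibitor of growth. Compound 1 `COC(=O)[C@@]1(C)CCC=C2[C@@H]1CC[C@@H](C)[C@]2(C)Cc1c(C)[nH]c2ccc(C(F)(F)F)cc12` gives 16000 nM in this assay. Compound 2 `COC(=O)[C@@]1(C)CCC=C2[C@@H]1CC[C@@H](C)[C@]2(C)Cc1c(C=O)[nH]c2ccccc12` gives 7500 nM in this assay. Compound 3 `COC(=O)[C@@]1(C)CC[C@@H]2C3=C1CC[C@@H](C)[C@]3(C)C[C@@H]1c3cc(C)ccc3N[C@H]21` gives 15000 nM in this assay. On these numbers compound 3 sits within the scatter of compound 1 and also within the scatter of compound 2, so the three cannot be separated from one another by this assay.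

Compound 4 `COC(=O)[C@@]1(C)CC[C@@H]2C3=C1CC[C@@H](C)[C@]3(C)C[C@@H]1c3cc(F)ccc3N[C@H]21` differs from compound 3 in a single place: fluoro in place of methyl on an aromatic carbon. For the measured compounds named here, no pair of measured compounds in this set differs by such a swap, so no step of this kind can be read from the data, and the expectation rests on the structural change alone. A single-atom exchange of this sort on an aromatic ring is expected to move the number little, if at all, with no direction favoured beyond the scatter. The step expected is no change at the digits printed from compound 3 to compound 4 (within the scatter). Compound 4 is therefore estimated at 15000 nM in this assay, with a range from 7000 nM to 35000 nM.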

Compound 4, concentration for 50% growth inhibition: 18000 nM
Estimate against measurement, compound 4: 1.2-fold (0.08 log units) below; the measured number falls inside the stated range.
By their numbers in this assay, from the lowest: compounds 2, 3, 1 and 4 (each within the scatter of the next, the first and the last beyond it).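

For the compounds shown here, the swap gives the first reading of a single change in this set: fluoro in place of methyl on an aromatic carbon, meta to a fused ring and para to a fused ring, gives a 1.2-fold higher number from compound 3 to compound 4 (0.08 log units; within the scatter) in this assay. Going by these compounds alone, at this position, then, the assay does not tell these two groups apart, something the earlier compounds could not show, as no two of them differ in one place only. No measurement shown here offers an explanation for this result.

The compounds shown leave open whether an amine, a carboxylic acid or a longer chain such as propyl on this aromatic carbon would stand apart from compound 3 beyond the scatter in this assay. They also leave open whether fluoro in place of methyl would read the same way elsewhere on the aromatic ring or on the core of compound 1.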